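Extending the amine arm on a thymidine analogue

The source may report more compounds than this note shows. Statements on the series, on what has been measured and on what is new or still open speak of the compounds shown alone.

Of the compounds shown here, two have been measured so far in an assay on BHK21 (C13) cells (Mesocricetus auratus) for inhibition of thymidine kinase, cytosolic (Cricetulus griseus), using Lineweaver-Burk analysis; on this read-out higher numbers stand for weaker inhibition and lower numbers for stronger inhibition. Compound 1 `N#Cc1cn([C@H]2C[C@H](O)[C@@H](CO)O2)c(=O)[nH]c1=O` gives 220000 nM. Compound 2 `CC(=O)NC[C@H]1O[C@@H](n2cc(C)c(=O)[nH]c2=O)C[C@@H]1O` gives 6500000 nM, the higher of the two numbers, and its gap to compound 1 lies beyond the usual scatter, so compound 2 is the weaker inhibitor of the pair.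

Compound 3 `CC(=O)NCCNC[C@H]1O[C@@H](n2cc(C)c(=O)[nH]c2=O)C[C@@H]1O` differs from compound 2 in one place: 2-acetamidoethyl in place of acetyl on an amine nitrogen, so the acetamido group grows into a (2-acetamidoethyl)amino group while the rest of the molecule stays the same. For the measured compounds named here, no measured pair of compounds shows a change of this kind, so there is no earlier step to lean on. The step expected here, a 1.3-fold lower number from compound 2 to compound 3 (0.11 log units; within the scatter), is small and may not reach beyond the scatter in either direction. For compound 3 the estimated value in this assay is 5000000 nM, with a range from 1500000 nM to 20000000 nM.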

Compound 3, inhibition constant: 250000 nM
Compound 3: middle estimate off by 20-fold (1.30 log units), on the high side; measured number outside the range, below it.
By their numbers in this assay, from the lowest: compounds 1 and 3 (each within the scatter of the next); then compound 2.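

This position on the thymidine analogue responds strongly to a change in the arm: in this assay, putting 2-acetamidoethyl in place of acetyl on the amine nitrogen gives a 26-fold lower number from compound 2 to compound 3 (1.41 log units; beyond the scatter), so the extended arm goes with stronger inhibition. For the compounds shown here, until now no two compounds differed in only one place, so no single change could be followed. Nothing measured here accounts for this step, which stands as an observation without an explanation.

From the compounds shown here alone, it remains open which part of the new arm matters: the amine nitrogen that is kept, the ethyl link or the acetamido end. A plain 2-aminoethyl group on that nitrogen would help separate these parts, while a longer chain such as 3-acetamidopropyl would test whether the length of the arm counts.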